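The source may hold more compounds than are shown below. What is called first, only, known or untested is meant among the compounds shown, and "the series" means these compounds.

Compounds measured so far in an assay on RBL cells for inhibition of Polyunsaturated fatty acid 5-lipoxygenase (Rattus norvegicus); a higher number here means a weaker inhibitor, a lower number a stronger inhibitor:
compound 1 `CC(=O)N(O)C(C)c1ccc(OCCc2ccccc2)cc1` gives 410 nM
compound 2 `COc1cccc(OC)c1C(=O)N(O)C(C)c1ccc2oc(-c3ccccc3)cc2c1` gives 3000 nM
compound 3 `CCCCCCCCCCc1cc2cc(C(C)N(O)C(=O)CCCC(=O)OC)ccc2o1` gives 150 nM

Compound 2 stands at the highest of the three numbers in this assay. Its nearest neighbour is compound 1, whose number is lower by a gap beyond the scatter; compound 3 stands further off again, also beyond the scatter. Compound 2 is thus the weakest inhibitor of the three on these numbers.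

Compound 4 `CC(c1ccc2oc(-c3ccccc3)cc2c1)N(O)C(=O)CO` has not been measured in this assay. It differs from compound 2 in one place: hydroxymethyl in place of 2,6-dimethoxyphenyl on a carbonyl carbon. Among the compounds with values here, no measured pair differs in only this place, so the size of the step cannot be read from the data. A step towards a lower number is expected, of moderate size, a 7.5-fold lower number from compound 2 to compound 4 (0.88 log units; beyond the scatter), because compound 1 gives 410 nM and compound 3 gives 150 nM, both carrying other groups on the same carbonyl carbon and both giving lower numbers than compound 2. For compound 4 the estimate in this assay is 400 nM, with a range from 120 nM to 1500 nM.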

Compound 4, half-maximal inhibitory concentration: 700 nM
Compound 4: the middle estimate sits 1.8-fold (0.24 log units) below what was measured; the measured number falls inside the stated range.
By their numbers in this assay, from the lowest: compound 3; then compounds 1 and 4 (each within the scatter of the next); then compound 2.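

In this assay, within the data shown here, hydroxymethyl in place of 2,6-dimethoxyphenyl on a carbonyl carbon gives a 4.3-fold lower number from compound 2 to compound 4 (0.63 log units; beyond the scatter), the only step here that isolates this position. On the shared core, inhibition at this level therefore does not require the six-membered aromatic ring of the leaving group, and the ringless hydroxymethyl group gives the lower number. No measurement is available that bears on the origin of this step.

The compounds shown leave open whether the step follows from losing the 2,6-dimethoxyphenyl group or from gaining the hydroxyl oxygen, a distinction that a methyl group on the same carbonyl carbon could test. From the compounds shown here alone, how an aminomethyl group, a carboxylic acid or a longer chain would fare at this position on the same core also remains open.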